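The compounds below may be only part of what the source reports. "The series", "measured", "known", "first", "only" and "open" are said of these compounds alone.

Measured so far:
compound 1 `O=C(Nc1cc(C(F)(F)F)ccc1Nc1ccc(Br)cc1)c1ccncc1` gives "not active" (no number reported) in a functional assay on Jurkat cells (Homo sapiens) for cytotoxicity, read by MTT assay, with a stated time of 48 h; a lower number here means a stronger inhibitor, a higher number a weaker inhibitor;
compound 2 `CCN(CC)c1ccc(C(F)(F)F)cc1NC(=O)c1cccnc1` gives "not active" (no number reported) in this assay;
compound 3 `O=C(Nc1cc(C(F)(F)F)ccc1NC1CCCCC1)c1ccncc1` gives 80900 nM in this assay.

Compound 3 is thus the only one of the three with a number at all, and that number is a weak one; compound 1 and compound 2 show no activity in this assay. The next compound, compound 4 `O=C(Nc1cc(C(F)(F)F)ccc1NC1CCCCC1)c1cccnc1`, keeps every atom of compound 3 and changes only one thing: pyridin-3-yl in place of pyridin-4-yl on a carbonyl carbon. Nothing measured here tells how large such a swap is, so no step beyond the usual scatter is expected, with a slight lean toward a weaker compound, since compound 2 also carries pyridin-3-yl and gives "not active" (no number reported). Compound 4 is expected at 100000 nM, between 40000 nM and 250000 nM, a step of a 1.2-fold higher number from compound 3 to compound 4 (0.09 log units; within the scatter).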

Compound 4, half-maximal inhibitory concentration: "not active" (no number reported)
For compound 4 the study gives words and no number, and the estimate cannot be compared.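

No step can be read from compound 3 to compound 4, as compound 4 has no number to compare. The compounds shown leave open how far pyridin-3-yl in place of pyridin-4-yl shifts activity. No measurement here offers an explanation for the result.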